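Ring-amine substituent exchange: notes toward compound 4

A few compounds are considered here, and "the series" means these few. Any claim that something is new, unique, unknown or untested is made for them only; others in the source may bear on it.

Measured compounds:
compound 1 `CC(C)(C)OC(=O)N1CCC(Oc2cccc3c2ccn3-c2ccc(S(C)(=O)=O)cc2)CC1` — 28%
compound 2 `CC(C)OC(=O)N1CCC(Oc2ncnc3c2CCN3c2ccc(-c3nccs3)cc2F)CC1` — 74%
compound 3 `CC(C)COC(=O)N1CCC(Oc2ncnc3c2CCN3c2ccc(S(C)(=O)=O)cc2F)CC1` — 94%

In a functional assay on CHO-K1 cells with Glucose-dependent insulinotropic receptor (Homo sapiens) as the target, read by a luciferase reporter, with a stated time of 5 h (a lower number here means a smaller maximal response, a higher number a larger maximal response), compound 3 gives 94%, the highest of the three numbers; compound 2 gives 74% and compound 1 gives 28%, both gaps lying beyond the scatter. Compound 4 `CCS(=O)(=O)N1CCC(Oc2ncnc3c2CCN3c2ccc(S(C)(=O)=O)cc2F)CC1` differs from compound 3 by ethylsulfonyl in place of isobutoxycarbonyl on an amine nitrogen in a ring. Going by the values given here, no measured pair shows this exchange on the shared core, so the direction of the step cannot be read from the series. A small to moderate decrease in this assay is expected, though a step within the scatter would also be consistent with what is known. The step from compound 3 to compound 4 is estimated as a number 19 percentage points lower from compound 3 to compound 4 (beyond the scatter). Compound 4 is estimated at 75%, with a range from 45% to 100%.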

Compound 4, largest response reached (reported as percent of maximum), in percent of the reference or control that the assay uses: 51%
Compound 4: middle estimate off by 24 percentage points, on the high side; measured number inside the range.
By their numbers in this assay, from the lowest: compound 1; then compound 4; then compound 2; then compound 3.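

In this assay, going by these compounds alone, ethylsulfonyl in place of isobutoxycarbonyl on the amine nitrogen in the ring gives a number 43 percentage points lower from compound 3 to compound 4 (beyond the scatter), the first single-place comparison. The group on this nitrogen therefore has a large influence on the maximal response on the shared core. Nothing available bears on the cause of this step. As far as these compounds go, it remains open whether the loss follows the sulfonyl link or the ethyl chain. Isobutylsulfonyl or ethoxycarbonyl on the same nitrogen would separate the two.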